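Expecting the Cytotoxicity of Compound 4

This account rests on a few compounds, and the source may have more. Where it says the series, first, only, none or still open, it means among the compounds named here.

Of the compounds shown here, three built on one shared core have been tested in a toxicity assay on WI-38 cells (Homo sapiens) for cytotoxicity, read by MTT assay, with a stated time of 48 h; a lower number here means a stronger inhibitor, a higher number a weaker inhibitor. Compound 1 `O=C(/C=C/c1ccc2c(c1)B(O)OC2)c1cccnc1` gives 76200 nM. Compound 2 `Cn1cccc1C(=O)/C=C/c1ccc2c(c1)B(O)OC2` gives only a limit, > 100000 nM. Compound 3 `Cc1ccc(C(=O)/C=C/c2ccc3c(c2)B(O)OC3)cc1` gives 22200 nM, the lowest of the two numbers: the step of a 3.4-fold lower number from compound 1 to compound 3 (0.54 log units; beyond the scatter) lies beyond the scatter, as does an at least 4.5-fold lower number from compound 2 to compound 3 (0.65 log units; beyond the scatter), whereas an at least 1.3-fold higher number from compound 1 to compound 2 (0.11 log units; that floor lies within the scatter) stays within it. Compound 4 `O=C(/C=C/c1ccc2c(c1)B(O)OC2)c1ccc([N+](=O)[O-])cc1` differs from compound 3 by nitro in place of methyl on an aromatic carbon. Among the compounds with values here, none of the measured steps touches this position: each of them exchanges the whole aryl group on the carbonyl carbon, and none involves a nitro group, so they offer no direct guide. The widest change seen in the set, an at least 4.5-fold lower number from compound 2 to compound 3 (0.65 log units; beyond the scatter), gives only a rough ceiling for how far a single substituent swap might move the number. For compound 4 the step of a 1.1-fold higher number from compound 3 to compound 4 (0.05 log units; within the scatter) is expected to stay within the scatter. In this assay compound 4 is estimated at 25000 nM, between 8000 nM and 80000 nM.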

Compound 4, half-maximal inhibitory concentration: 39300 nM
Compound 4: middle estimate off by 1.6-fold (0.20 log units), on the low side; low and high end bracket the measured number.
By their numbers in this assay, from the lowest: compounds 3, 4 and 1 (each within the scatter of the next, the first and the last beyond it). At a limit, above all of these: compound 2.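

Within the data shown here, compound 4 gives the first step in the set that changes only a substituent on the aryl group, not the whole group on the carbonyl carbon, and in this assay nitro in place of methyl amounts to a 1.8-fold higher number from compound 3 to compound 4 (0.25 log units; within the scatter). On an aromatic carbon para to a large group, methyl and nitro therefore cannot be told apart in this read-out, even though nitro brings hydrogen-bond acceptors and methyl has none, whereas exchanging the whole aryl group moved the number beyond the scatter in a 3.4-fold lower number from compound 1 to compound 3 (0.54 log units; beyond the scatter). Nothing among the data shown accounts for this step.

On these data alone, whether an amine, a carboxylic acid or a longer chain on this same carbon would also stay within the scatter remains open. This single pair also leaves open whether methyl and nitro would read alike elsewhere on the ring.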